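Swapping fluoro for methoxy on a weak antiproliferative compound

A few compounds are considered here, and "the series" means these few. Any claim that something is new, unique, unknown or untested is made for them only; others in the source may bear on it.

- compound 1 `CCn1cc(-c2nc3ccc([N+](=O)[O-])cc3o2)c(=O)c2cc(F)c(N3CCNC(C)C3)c(F)c21`: 1470 nM
- compound 2 `CCn1cc(-c2ccc(F)cc2)c(=O)c2cc(F)c(N3CCNCC3)cc21`: 11400 nM

Both values come from a functional assay on A549 cells (Homo sapiens) for antiproliferative activity, read by MTT assay, with a stated time of 48 h; on this read-out lower numbers stand for stronger inhibition and higher numbers for weaker inhibition. Compound 2 has the higher number of the two, so it is the weaker inhibitor of this pair, and the gap to compound 1 lies beyond the usual scatter. These two compounds differ in more than one place, so their gap says nothing about any single group.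

Compound 3 `CCn1cc(-c2ccc(OC)cc2)c(=O)c2cc(F)c(N3CCNCC3)cc21` is still unmeasured and keeps the whole of compound 2 except for one group: methoxy in place of fluoro on an aromatic carbon. This puts methoxy in place of fluoro on an aromatic carbon, para to a large group, turning a 4-fluorophenyl into a 4-methoxyphenyl. Among the compounds with values here, no measured pair shows what this swap does, so the best starting point is compound 2 at 11400 nM. In this assay, no shift beyond the scatter is expected from so small a change, and the range must stay wide in both directions. The expected change is a 1.1-fold lower number from compound 2 to compound 3 (0.06 log units; within the scatter). For compound 3 the estimate is 10000 nM, with an expected range of 4000 nM to 25000 nM.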

Compound 3, half-maximal inhibitory concentration: 11600 nM
For compound 3 the middle estimate is 1.2-fold (0.06 log units) below the measured one, within the range that was stated.
By their numbers in this assay, from the lowest: compound 1; then compounds 2 and 3 (each within the scatter of the next).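

In this assay, the change from 4-fluorophenyl to 4-methoxyphenyl gives a 1.0-fold higher number from compound 2 to compound 3 (0.01 log units; within the scatter), so the two compounds cannot be told apart on this read-out. Within the data shown here, this is the first step that isolates a single group: on an aromatic carbon, para to a large group, methoxy takes the place of fluoro, bringing two heavy atoms instead of one and a hydrogen-bond acceptor where fluoro counts none, and the number does not move beyond the usual scatter. No measurement of any property of these compounds accompanies this result, so the data offer no explanation for it.

This single pair cannot show whether the position tolerates other changes in general, since fluoro and methoxy both carry no net charge and neither has a hydrogen-bond donor. An amine or a carboxylic acid at the same place, a longer chain such as butoxy, or a phenyl ring with no group there at all would show whether anything at this position can shift the number in either direction.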